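Two Carboxamides Measured, an Anilide Awaited

This account rests on a few compounds, and the source may have more. Where it says the series, first, only, none or still open, it means among the compounds named here.

Compound 2: `CNC(=O)c1nc(-c2cc(OC)c(OC)c(OC)c2)n(-c2ccc(OC)cc2)n1` — 95%
Compound 1: `COc1ccc(-n2nc(C(N)=O)nc2-c2cc(OC)c(OC)c(OC)c2)cc1` — 92%

Of the compounds shown here, two have been tested in a functional assay on the whole organism for inhibition, with Rattus norvegicus as the target, read by paw edema, with stated times of 30 min and 3 h, at a dose of 0.28 mmol/kg by the oral route; on this read-out higher numbers stand for more inhibition at the one dose given (going by the name of the read-out) and lower numbers for less inhibition. Compound 1, `COc1ccc(-n2nc(C(N)=O)nc2-c2cc(OC)c(OC)c(OC)c2)cc1`, gives 92%, and compound 2, `CNC(=O)c1nc(-c2cc(OC)c(OC)c(OC)c2)n(-c2ccc(OC)cc2)n1`, gives 95%. Among the measured compounds shown here, the single measured step, a number 3 percentage points higher from compound 1 to compound 2 (within the scatter), puts methyl in place of hydrogen on the amide-type nitrogen; compound 2 holds the highest of the two numbers, but its distance from compound 1 lies within the scatter, so no order between them can be read.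

Compound 3, `COc1ccc(-n2nc(C(=O)Nc3cccc(F)c3)nc2-c2cc(OC)c(OC)c(OC)c2)cc1`, is not yet measured. It differs from compound 2 by 3-fluorophenyl in place of methyl on an amide-type nitrogen. For the measured compounds named here, only the step from compound 1 to compound 2 touches this nitrogen, and it was within the scatter, so nothing measured speaks to a ring entering there. Compound 3 is therefore expected to show a step of a number 10 percentage points lower from compound 2 to compound 3 (within the scatter), a modest drop allowed for by the wider change, landing at an estimated 85% with a range of 60% to 98%.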

Compound 3, a percentage reported as inhibition, in the whole organism at one dose (the size of the read-out at that dose, not a potency): 92%
Compound 3: the middle estimate sits 7 percentage points below what was measured; the range from low to high includes it.
By their numbers in this assay, from the lowest: compounds 1, 3 and 2 (each within the scatter of the next).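

In this assay, 3-fluorophenyl on the amide-type nitrogen gives a number 3 percentage points lower from compound 2 to compound 3 (within the scatter) and, set against the amide hydrogen, no change at the digits printed from compound 1 to compound 3 (within the scatter). Until now this nitrogen had carried only hydrogen or methyl; these steps show that it can also bear an aromatic ring while the read-out at this dose stays within the scatter of both smaller compounds. Nothing available explains this result.

Going by these compounds, what a plain phenyl without the fluorine, a benzyl group or a carboxylic acid in place of the whole carboxamide would give remains open. The read-out reports one dose and is not a potency, so whether these three compounds would separate at a lower dose also stays unanswered.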